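Bromine position along a diol chain

The source may hold more compounds than are shown below. What is called first, only, known or untested is meant among the compounds shown, and "the series" means these compounds.

Measured compounds:
compound 1, `OCCCCCCCC(Br)CCCCO`, 2340000 nM
compound 2, `OCCCCCCCCCC(Br)CCO`, 800000 nM
compound 3, `OCCCCCCC(Br)CCCCCO`, 2260000 nM

The three measured compounds share the same atoms and differ only in where the bromine sits along the chain. In a physicochemical assay for solubility, at pH 7.8 (on this read-out lower numbers stand for lower solubility and higher numbers for higher solubility), compound 1 gives 2340000 nM and compound 3 gives 2260000 nM; these two lie within the scatter of each other. Compound 2 stands lowest of the three in this assay, with 800000 nM, and its gap to both compound 1 and compound 3 is beyond the scatter.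

Compound 4, `OCCCCCCCCCCC(Br)CO`, has not been measured. It differs from compound 2 in one place: 2-bromo-3-hydroxypropyl in place of 1-bromo-3-hydroxypropyl on a saturated chain carbon, nine bonds along the chain from an oxygen on a saturated carbon. Going by the values given here, no pair of measured compounds differing in a single place has been compared, so the size of such a step is unknown from the data. The bromine of compound 4 sits closer to one chain end than in compound 2, which itself sits below compound 1 and compound 3 in this assay. The step from compound 2 to compound 4 is therefore expected to be small, a 1.2-fold lower number from compound 2 to compound 4 (0.09 log units; within the scatter), most likely within the scatter and, if anything, downward. Compound 4 is expected to give about 650000 nM, between 300000 nM and 1500000 nM.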

Compound 4, solubility: 725000 nM
For compound 4 the middle estimate is 1.1-fold (0.05 log units) below the measured one; measured number inside the range.
By their numbers in this assay, from the lowest: compounds 4 and 2 (each within the scatter of the next); then compounds 3 and 1 (each within the scatter of the next).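

The change to 2-bromo-3-hydroxypropyl in place of 1-bromo-3-hydroxypropyl, on a saturated chain carbon, nine bonds along the chain from an oxygen on a saturated carbon, gives in this assay a 1.1-fold lower number from compound 2 to compound 4 (0.04 log units; within the scatter). Going by these compounds alone, this is the first step that can be read between two compounds differing in one place, and it gives the earlier compounds' spread of values a measured reference. At this place the two groups, which have the same atoms and the same counts of hydrogen-bond donors and acceptors, cannot be told apart in this read-out, and nothing measured speaks to the reason for that.

What the compounds shown leave open is whether a step of this size would also be seen if the hydroxyl on the shifted group gave way to an amine or a carboxylic acid, or if chlorine stood in place of the bromine. They also leave open whether a longer chain carrying the same two groups would give a step of the same size.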